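This account rests on a few compounds, and the source may have more. Where it says the series, first, only, none or still open, it means among the compounds named here.

Compound 1 `COc1ccc2nc(NC(=O)CCC(=O)c3ccccc3)sc2c1`: 30 mg/kg
Compound 2 `CC(=O)c1ccc2nc(NC(=O)CCC(=O)c3ccccc3)sc2c1`: 100 mg/kg
Compound 3 `COc1ccc2nc(NC(=O)c3ccccc3C(=O)c3ccccc3)sc2c1`: 100 mg/kg

In a functional assay on the whole organism with Mus musculus as the target, in the maximal electroshock model, with a stated time of 4 h (a lower number here means that less compound is needed, a higher number that more compound is needed for the effect), compound 1 gives 30 mg/kg, the lowest of the three numbers. Compound 2 differs from compound 1 by one change acetyl in place of methoxy on an aromatic carbon and in this assay compound 2 gives 100 mg/kg, so the change gave a 3.3-fold higher number from compound 1 to compound 2 (0.52 log units; beyond the scatter). Compound 3 carries a different core; the difference between the two cores is not broken down here. In this assay compound 3 gives 100 mg/kg, level with compound 2 at the digits printed.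

Compound 4 `CC(=O)c1ccc2nc(NC(=O)c3ccccc3C(=O)c3ccccc3)sc2c1` is not yet measured. It differs from compound 3 by acetyl in place of methoxy on an aromatic carbon, the same change as that from compound 1 to compound 2. Starting from the higher number of compound 3, a step of about the earlier size is expected, a 2.5-fold higher number from compound 3 to compound 4 (0.40 log units; beyond the scatter), because a 3.3-fold higher number from compound 1 to compound 2 (0.52 log units; beyond the scatter) is the only guide. Compound 4 is thus estimated at 250 mg/kg, between 100 mg/kg and 600 mg/kg.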

Compound 4, minimum effective dose: 300 mg/kg
The estimate for compound 4 lay 1.2-fold (0.08 log units) below the measured number; the measured number falls inside the stated range.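

In this assay, acetyl in place of methoxy on an aromatic carbon gave a 3.0-fold higher number from compound 3 to compound 4 (0.48 log units; beyond the scatter). The change therefore carried over from one core to the other in the same direction and at about the same size: the same change on two cores in this assay, a 3.3-fold higher number (0.52 log units; beyond the scatter) from compound 1 to compound 2 and a 3.0-fold higher number (0.48 log units; beyond the scatter) from compound 3 to compound 4, 1.1-fold (0.05 log units) apart, within the scatter of two such steps. This holds for these two cores in this assay only; it does not show that the step would recur on a further core, and it does not explain why the number rises.

The compounds shown leave open what other groups on this aromatic carbon would give, such as an amine, a carboxylic acid or a longer chain. They also leave open whether the step would persist in any other assay.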